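The source may report more compounds than this note shows. Statements on the series, on what has been measured and on what is new or still open speak of the compounds shown alone.

Measured compounds in an assay on CHO cells for antagonist activity at transient receptor potential cation channel subfamily V member 1 (Homo sapiens), read by FLIPR; a lower number here means a stronger inhibitor, a higher number a weaker inhibitor:
compound 1, `CC(C(=O)NCc1ccc(C(F)(F)F)cc1N1CCN(C2CCCCC2)CC1)c1ccc(NS(C)(=O)=O)c(F)c1`, gives 13.8 nM
compound 2, `CC(C(=O)NCc1ccc(C(F)(F)F)cc1OCc1ccccc1)c1ccc(NS(C)(=O)=O)c(F)c1`, gives 0.9 nM

Compound 2 stands at the lowest of the two numbers; its nearest neighbour, compound 1, lies at a higher number, as the step of a 15-fold lower number from compound 1 to compound 2 (1.19 log units; beyond the scatter) shows. Compound 3, `CC(C(=O)NCc1ccc(C(F)(F)F)cc1SCCCO)c1ccc(NS(C)(=O)=O)c(F)c1`, has not yet been measured in this assay. It differs from compound 2 in one place: (3-hydroxypropyl)sulfanyl in place of benzyloxy on an aromatic carbon.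

Among the compounds with values here, only one measured step touches this position, a 15-fold lower number from compound 1 to compound 2 (1.19 log units; beyond the scatter), and it was large, so this part of the shared core evidently matters for the read-out. Of the two groups measured so far, benzyloxy gave the lower number. Within the data shown here, a third group at the same place is untested, so the direction of the step cannot be read from the data with confidence; the weight of the one known step suggests a rise in the number is more likely than a further fall. Compound 3 is therefore expected to show a step of an 11-fold higher number from compound 2 to compound 3 (1.05 log units; beyond the scatter), and its inhibition constant is estimated at 10 nM, within a range from 2 nM to 60 nM.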

Compound 3, inhibition constant: "not active" (no number reported)
Compound 3 has no reported number here, so the estimate cannot be set against anything.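

In this assay, within the data shown here, compound 3 is reported only as "not active", with no number, so no step from compound 2 to compound 3 can be read. No measurement shown here bears on this result. The compounds shown leave open whether the sulfanyl link, the hydroxypropyl chain, or both together accompany this outcome.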